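Methoxy on the benzoyl group of compound 3

This account rests on a few compounds, and the source may have more. Where it says the series, first, only, none or still open, it means among the compounds named here.

In a functional assay on A549 cells (Homo sapiens) for inhibition, read by MTT assay, with a stated time of 24 h (a lower number here means a stronger inhibitor of growth, a higher number a weaker inhibitor of growth), compound 1 `COc1ccccc1C(=O)n1c(-c2cn(C)c3ccccc23)nc2ccccc21` gives 12300 nM, compound 2 `COc1ccc2c(c1)c(-c1nc3ccccc3n1C(=O)c1ccccc1OC)cn2C` gives 11900 nM and compound 3 `Cn1cc(-c2nc3ccccc3n2C(=O)c2ccccc2)c2cc(Br)ccc21` gives 23100 nM. Compound 3 stands within the scatter of both others, so the three values do not separate.

The next change leads to compound 4 `COc1ccccc1C(=O)n1c(-c2cn(C)c3ccc(Br)cc23)nc2ccccc21`: methoxy in place of hydrogen on an aromatic carbon, ortho to a large group, turning benzoyl into (2-methoxyphenyl)carbonyl (methoxy in place of hydrogen on an aromatic carbon). Among the compounds with values here, the only measured methoxy step is a 1.0-fold lower number from compound 1 to compound 2 (0.01 log units; within the scatter), within the scatter, but it lies elsewhere in the molecule and bears only indirectly. Within the data shown here, no measured pair isolates this exact change. Compound 1 and compound 2 already carry the 2-methoxyphenyl group and stand within the scatter of compound 3, though they also differ from it elsewhere.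

No step beyond the scatter is therefore expected in this assay. The estimated step is a 1.4-fold lower number from compound 3 to compound 4 (0.16 log units; within the scatter). Compound 4 is expected at 16000 nM, with an estimated range of 8000 nM to 32000 nM.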

Compound 4, concentration for 50% growth inhibition: 12800 nM
The estimate for compound 4 lay 1.3-fold (0.10 log units) above the measured number; low and high end bracket the measured number.
By their numbers in this assay, from the lowest: compounds 2, 1, 4 and 3 (each within the scatter of the next).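

In this assay the methoxy change now has a direct reading at the benzoyl group, where phenyl becomes 2-methoxyphenyl (a 1.8-fold lower number from compound 3 to compound 4 (0.26 log units; within the scatter)), and it does not separate the pair. With the 2-methoxyphenyl group in place, the other substituted site does not separate hydrogen, bromo and methoxy either, whether bromo replaces hydrogen (a 1.0-fold higher number from compound 1 to compound 4 (0.02 log units; within the scatter)) or methoxy (a 1.1-fold higher number from compound 2 to compound 4 (0.03 log units; within the scatter)). The methoxy change has now been read at two sites, and the two readings do not separate from each other: the same change on two cores in this assay, a 1.0-fold lower number (0.01 log units; within the scatter) from compound 1 to compound 2 and a 1.8-fold lower number (0.26 log units; within the scatter) from compound 3 to compound 4, 1.7-fold (0.24 log units) apart, within the scatter of two such steps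

Going by these compounds, whether an amine or a carboxylic acid on the benzoyl group would give a step beyond the scatter remains open. No step shown at either site leaves the scatter, so these compounds do not establish how much either site can influence growth inhibition in this assay at all.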